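The source may hold more compounds than are shown below. What is called first, only, known or untested is meant among the compounds shown, and "the series" means these compounds.

Of the compounds shown here, three have so far been measured in an assay on HEK293 cells for agonist activity at transient receptor potential cation channel subfamily M member 8 (Homo sapiens), read by fluorescence and calcium flux, with a stated time of 15 min; on this read-out higher numbers stand for an effect only at larger amounts of compound and lower numbers for an effect already at smaller amounts. Compound 1 `CCN(Cc1ccoc1)C(=O)COc1ccc(C)cc1` gives 136 nM, compound 2 `CCN(Cc1cccs1)C(=O)COc1ccc(C(F)(F)F)cc1` gives 236 nM, and compound 3 `CCN(Cc1cccs1)C(=O)COc1cc(C)ccc1O` gives 24 nM. Among these, the number from compound 2 is the largest; its gap to compound 1 is within the usual scatter, so the two cannot be told apart, while compound 3 lies beyond the scatter at a smaller number.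

Compound 4 `CCN(Cc1cccs1)C(=O)COc1ccc(C(C)C)cc1` has not yet been measured. It differs from compound 2 in a single place: isopropyl in place of trifluoromethyl on an aromatic carbon. Going by the values given here, no pair of measured compounds differs in exactly this way, so nothing among the measured numbers shows directly what this exchange does. What can be said is that compound 1 carries a methyl where compound 2 carries a trifluoromethyl, and the two numbers from compound 1 and compound 2 sit within the scatter of each other, which suggests that exchanging one small group for another at this position need not move the number far. The expected step is therefore small, a 1.5-fold lower number from compound 2 to compound 4 (0.17 log units; within the scatter), with at most a slight lean toward a smaller number. Compound 4 is estimated at 160 nM, within a range from 50 nM to 500 nM.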

Compound 4, half-maximal effective concentration: 397 nM
The estimate for compound 4 lay 2.5-fold (0.39 log units) below the measured number; low and high end bracket the measured number.
By their numbers in this assay, from the lowest: compound 3; then compounds 1, 2 and 4 (each within the scatter of the next, the first and the last beyond it).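

In this assay, trading trifluoromethyl for isopropyl at the place para to a large group gives a 1.7-fold higher number from compound 2 to compound 4 (0.23 log units; within the scatter), which means that compound 2 and compound 4 cannot be told apart. Going by these compounds alone, this is the first pair in which only the group at this place differs, and it shows that an all-carbon branched group and a fluorine-bearing group can stand here without a change that rises above the scatter. No measurement shown here offers an explanation for how close these two compounds lie.

On these data alone, both groups at this place carry no hydrogen-bond donors or acceptors and no net charge, so it remains open whether an amine, a carboxylic acid or a longer chain such as n-hexyl would leave the number where it is. Compound 3 also differs from compound 2 in more than one place, and the compounds shown do not reveal which of those differences, if any, goes with the number of compound 3.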